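From methyl to propyl: compound 2 to compound 3

The source may hold more compounds than are shown below. What is called first, only, known or untested is meant among the compounds shown, and "the series" means these compounds.

Of the compounds shown here, two have a number so far. In an ADME assay on liver (Mus musculus) for metabolic stability, read by LC-MS, using microsomes and NADPH (a higher number here means that more of the compound is left, a lower number that less of the compound is left), compound 2 (`Cc1cc(CN(C)C(CC(=O)O)c2ccc(Cl)cc2)ccc1OCCn1c(=O)ccn(C)c1=O`) gives 68% as the higher of the two, and compound 1 (`Cc1cc(CN(CCC(F)(F)F)C(CC(=O)O)c2ccc(Cl)cc2)ccc1OCCN1C(=O)CCC1=O`) gives 56% as the lower, a gap beyond the usual scatter. These two differ in more than one place, so the gap cannot be tied to a single change.

Compound 3 (`CCCN(Cc1ccc(OCCn2c(=O)ccn(C)c2=O)c(C)c1)C(CC(=O)O)c1ccc(Cl)cc1`) is still unmeasured and departs from compound 2 in one place (ethyl in place of hydrogen on a saturated chain carbon bound to an amine nitrogen): ethyl in place of hydrogen on a saturated chain carbon bound to an amine nitrogen, which also reads as methyl to propyl. Among the compounds with values here, no step between measured compounds covers this change, so the expectation rests on thin evidence. Within the data shown here, compound 1, the only measured compound without a methyl on that amine nitrogen, gives 56% as its number, which points weakly downward. The step of a number 10 percentage points lower from compound 2 to compound 3 (within the scatter) is expected to be a modest fall, close to the size of the scatter. Compound 3 is expected at 58% with an estimated range of 42% to 72% in this read-out.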

Compound 3, percent of the compound remaining: 23%
For compound 3 the middle estimate is 35 percentage points above the measured one; measured number outside the range, below it.
By their numbers in this assay, from the lowest: compound 3; then compound 1; then compound 2.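

In this assay, within the data shown here, ethyl in place of hydrogen on a saturated chain carbon bound to an amine nitrogen gives the first step that can be tied to a single place: a number 45 percentage points lower from compound 2 to compound 3 (beyond the scatter). The earlier pair differed in more than one place, so only now is it shown that this place alone can move the read-out by a large amount, with the change from methyl to propyl and the rest of the structure held constant. Nothing at hand bears on why the step is this large, and the result stands as an observation without an explanation.

As far as these compounds go, with only methyl and propyl compared directly, the shape of the response to chain length remains open, including whether an ethyl chain on this amine nitrogen would fall close to compound 2 or close to compound 3. Also open, from the compounds shown here alone, is whether a propyl chain carrying a hydroxyl group, or a cyclopropyl group in its place, would keep compound 2's standing in this assay, and compound 1 cannot settle this, as it differs from both compounds in more than one place.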